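The source may report more compounds than this note shows. Statements on the series, on what has been measured and on what is new or still open speak of the compounds shown alone.

Compound 1 `CCOC(=O)C1=Cc2ccccc2OC1(OCc1cn(CC(=O)Nc2cccc(Cl)c2)nn1)C(F)(F)F` gives 10100 nM in a functional assay on DU-145 cells (Homo sapiens) for inhibition, read by MTT assay, with a stated time of 24 h; a higher number here means a weaker inhibitor, a lower number a stronger inhibitor. Compound 3 `Cc1ccc(-c2cc(COC3(C(F)(F)F)Oc4ccccc4C=C3C(=O)O)on2)cc1` is the free acid of the shared core and gives 41400 nM in this assay. Compound 2 `CCOC(=O)C1=Cc2ccccc2OC1(OCc1cc(-c2ccc(C)cc2)no1)C(F)(F)F` is its ethyl ester. In this assay compound 2 is reported only as a limit, > 150000 nM, so it has no firm number of its own and stands at the weak end of the values shown. Among the compounds with values here, the one measured step leading out of compound 2 is an at least 3.6-fold lower number from compound 2 to compound 3 (0.55 log units; beyond the scatter), and its size is set by the limit of > 150000 nM in this assay, at which 1 of the 3 values shown sits, the limit on which compound 2 sits. Compound 4 `CCOC(=O)C1=Cc2ccccc2OC1(OCc1cc(-c2ccc(Cl)cc2)no1)C(F)(F)F` differs from compound 2 by chloro in place of methyl on an aromatic carbon. Within the data shown here, no measured pair carries this exchange, and the ethyl ester of compound 2 is kept, so no step beyond the scatter is anticipated. The expected step from compound 2 is therefore a number no higher from compound 2 to compound 4 (the limit leaves the size open). Compound 4 is estimated at 150000 nM in this assay, between 50000 nM and 400000 nM, with a real chance that only a limit is reported again.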

Compound 4, half-maximal inhibitory concentration: 18200 nM
Compound 4: the middle estimate sits 8.2-fold (0.92 log units) above what was measured, outside the stated range (below it).
By their numbers in this assay, from the lowest: compounds 1 and 4 (each within the scatter of the next); then compound 3. At a limit, above all of these: compound 2.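

The exchange of 4-methylphenyl for 4-chlorophenyl is the first change shown on this aromatic ring, and in this assay it gives an at least 8.2-fold lower number from compound 2 to compound 4 (0.91 log units; beyond the scatter). The earlier step out of compound 2, an at least 3.6-fold lower number from compound 2 to compound 3 (0.55 log units; beyond the scatter), replaced the ethyl ester with the free acid, whereas this one keeps the ester, so a number beyond the limit of the series no longer depends on losing that ester. Compound 2 is a limit and not a number, so the new step has only a bound on its size, set by: the limit of > 150000 nM in this assay, at which 1 of the 4 values shown sits.

From the compounds shown here alone, it remains open how a methoxy group, an amine or a plain hydrogen would read at this place on the aromatic ring. Also open, going by these compounds, is whether 4-chlorophenyl gives a comparable step on the free acid, compound 3.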